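Three stable compounds and a methoxypyridine to come

This account rests on a few compounds, and the source may have more. Where it says the series, first, only, none or still open, it means among the compounds named here.

Values in an ADME assay on microsomes from liver (Homo sapiens) for metabolic stability, read by LC-MS, with NADPH named in the record, with a stated time of 60 min, tested at 1 uM, in the absence of a further agent (on this read-out lower numbers stand for a less stable compound and higher numbers for a more stable compound), follow, each one a limit:
- compound 1 `CC(=O)N[C@@H]1CCN(c2cc(C)nn3c(-c4ccc(C(F)(F)F)cc4)c(C)nc23)C1` gives > 95%
- compound 2 `COc1ccc(-c2c(C)nc3c(N4CC[C@@H](NC(C)=O)C4)cc(C)nn23)cc1F` gives > 95%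
- compound 3 `CSc1ccc(-c2c(C)nc3c(N4CC[C@@H](NC(C)=O)C4)cc(C)nn23)cc1` gives > 95%

Compound 3 stands at the limit of > 95% in this assay, at which 3 of the 3 values shown sit, which is a limit and not a number. Compound 4 `COc1ccc(-c2c(C)nc3c(N4CC[C@@H](NC(C)=O)C4)cc(C)nn23)cn1` carries 6-methoxypyridin-3-yl in place of 4-(methylsulfanyl)phenyl on an aromatic carbon, and 6-methoxypyridin-3-yl in place of 4-(methylsulfanyl)phenyl on an aromatic carbon is the whole difference. Both a step that the two limits leave unreadable from compound 2 to compound 3 and a step that the two limits leave unreadable from compound 1 to compound 3 bear on this change, yet neither gives a size. Compound 2 gives > 95% as a limit with 3-fluoro-4-methoxyphenyl in that place. No step beyond the scatter is expected in this assay and a number at least 2 percentage points lower from compound 3 to compound 4 (that floor lies within the scatter) is the estimated step here. Compound 4 is expected between 80% and 100% with 93% as the best estimate.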

Compound 4, percent of the compound remaining: > 95%
Compound 4 was reported as a limit (the forecaster's own chance of this, stated with the estimate: 55%); middle value at least 2 percentage points away from the limit.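

Compound 4, like compound 1, compound 2 and compound 3, gives only a limit in this assay, so no step among these compounds can be read: the limit of > 95% in this assay, at which 4 of the 4 values shown sit.

As far as these compounds go, whether any of these four compounds differs in stability from the others stays open.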